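Trifluoromethoxy for methyl on a diaminoquinazoline-type anilino series

A few compounds are considered here, and "the series" means these few. Any claim that something is new, unique, unknown or untested is made for them only; others in the source may bear on it.

Measured compounds:
compound 1 `Cc1ccc(Nc2ccc3nc(N)nc(N)c3n2)cc1`, 2630 nM
compound 2 `Nc1nc(N)c2nc(Nc3ccc(F)c(F)c3)ccc2n1`, 2250 nM
compound 3 `Nc1nc(N)c2nc(Nc3cc(F)c(F)c(F)c3)ccc2n1`, 1810 nM

Three anilino compounds on a shared core have been tested in an ADME assay on isolated protein for inhibition of Dihydrofolate reductase (Homo sapiens), using NADPH; a lower number here means a stronger inhibitor, a higher number a weaker inhibitor. Compound 1 carries a methyl group on the anilino ring and gives 2630 nM. Compound 2 gives 2250 nM and compound 3 gives 1810 nM. Among the measured compounds shown here, the three numbers lie close together: the gap from compound 1 to either compound 2 or compound 3 is within the scatter of this assay, so no compound stands apart from the others.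

For the measured compounds named here, the one step between measured compounds that differ in a single place is a 1.2-fold lower number from compound 2 to compound 3 (0.09 log units; within the scatter), which did not move the number beyond the scatter.

Compound 4 `Nc1nc(N)c2nc(Nc3ccc(OC(F)(F)F)cc3)ccc2n1` differs from compound 1 by trifluoromethoxy in place of methyl on an aromatic carbon. Only the fluoro-for-hydrogen step from compound 2 to compound 3 bears on a change that adds fluorine to the anilino ring, and it was small. On that basis a step from compound 1 to compound 4 of about a 1.3-fold lower number from compound 1 to compound 4 (0.12 log units; within the scatter) is expected, a number not expected to move beyond the scatter in either direction. For compound 4 the estimate in this assay is 2000 nM, with a range from 800 nM to 5000 nM.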

Compound 4, half-maximal inhibitory concentration: 4130 nM
Compound 4: middle estimate off by 2.1-fold (0.31 log units), on the low side; low and high end bracket the measured number.
By their numbers in this assay, from the lowest: compounds 3, 2, 1 and 4 (each within the scatter of the next, the first and the last beyond it).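

In this assay the exchange of methyl for trifluoromethoxy on an aromatic carbon of the six-membered aromatic ring, para to a large group, gives a 1.6-fold higher number from compound 1 to compound 4 (0.20 log units; within the scatter) and stays within the scatter, although five heavy atoms enter where one leaves and a hydrogen-bond acceptor is added. Among the compounds shown here, this is the first sign that this place on the anilino ring can carry a much larger group without a shift that the assay can separate from the scatter, something the earlier fluoro-for-hydrogen step, which added a single fluorine, could not show. Nothing measured here on either group bears on this result, and the data offer no explanation for it.

On these data alone, whether an amine, a carboxylic acid or a longer alkyl chain at this place would move the number beyond the scatter remains open. Also open, as far as these compounds go, is how a plain hydrogen at this place would compare with methyl and trifluoromethoxy, and whether the same exchange would give a similar result on another core.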